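Furan Positional Isomers on a Pyrrolopyrimidine Nucleoside Scaffold

A few compounds are considered here, and "the series" means these few. Any claim that something is new, unique, unknown or untested is made for them only; others in the source may bear on it.

Measured so far:
- compound 1 `Nc1nc(N)c2c(-c3ccsc3)cn([C@@H]3O[C@H](CO)[C@@H](O)[C@H]3O)c2n1`: > 20000 nM
- compound 2 `O=c1[nH]cnc2c1c(-c1ccoc1)cn2[C@@H]1O[C@H](CO)[C@@H](O)[C@H]1O`: 14800 nM
- compound 3 `CN(C)c1ncnc2c1c(-c1ccoc1)cn2[C@@H]1O[C@H](CO)[C@@H](O)[C@H]1O`: > 20000 nM

In a functional assay on HCT-116 cells (Homo sapiens), read by MTT assay, with a stated time of 72 h (a higher number here means a weaker inhibitor, a lower number a stronger inhibitor), compound 1 reaches only the limit of the assay, > 20000 nM, and gives no number. Compound 3 likewise sits at the limit, > 20000 nM. Going by the values given here, compound 2 is therefore the only compound with a number in this assay, 14800 nM; the other two values rest at the limit of > 20000 nM in this assay, at which 2 of the 3 values shown sit.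

Compound 4 `O=c1[nH]cnc2c1c(-c1ccco1)cn2[C@@H]1O[C@H](CO)[C@@H](O)[C@H]1O` differs from compound 2 by one change: furan-2-yl in place of furan-3-yl on an aromatic carbon. The two are isomers with the same atoms. Among the compounds with values here, no measured pair in this set isolates this change, so no step size can be read from the data. The step from compound 2 to compound 4 is expected to be small, a 1.0-fold higher number from compound 2 to compound 4 (0.01 log units; within the scatter), not beyond the usual scatter. Compound 4 is therefore estimated at 15000 nM in this assay, within 5000 nM to 40000 nM.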

Compound 4, half-maximal inhibitory concentration: > 20000 nM
Compound 4: a limit, no number (the forecaster's own chance of this, stated with the estimate: 40%); at least 1.3-fold (0.12 log units) between middle value and limit.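

In this assay compound 4 gives > 20000 nM, which is a limit of the assay and not a number. Furan-2-yl in place of furan-3-yl on this aromatic carbon gives the first step in the set that can be read, an at least 1.3-fold higher number from compound 2 to compound 4 (0.13 log units; that floor lies within the scatter), so the pair does not show that the two furan isomers differ. With this result the one compound with a number stands alone among limits: the limit of > 20000 nM in this assay, at which 3 of the 4 values shown sit.

As far as these compounds go, the true size of this step stays open. So does the effect of an amine or a longer alkyl chain in place of the furan at this aromatic carbon.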